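A further methoxy on the nitro-bearing ring

The source may report more compounds than this note shows. Statements on the series, on what has been measured and on what is new or still open speak of the compounds shown alone.

Among the measured compounds shown here, in a functional assay on A549 cells (Homo sapiens) for antiproliferative activity, read by sulforhodamine B assay, with a stated time of 48 h (a lower number here means a stronger inhibitor, a higher number a weaker inhibitor), compound 1 `COc1cc(OC)c2sc(-c3ccc(N/C=C\C(=O)c4ccc(OC)c([N+](=O)[O-])c4)cc3)nc2c1` gives 5800 nM, the lower of the two numbers measured so far, and compound 2 `COc1ccc(C(=O)/C=C\Nc2ccc(-c3nc4cc(OC)c(OC)c(OC)c4s3)cc2)cc1[N+](=O)[O-]` gives 21200 nM. Compound 3 `COc1cc(OC)c2sc(-c3ccc(N/C=C\C(=O)c4cc(OC)c(OC)c([N+](=O)[O-])c4)cc3)nc2c1` has not yet been measured. It differs from compound 1 by methoxy in place of hydrogen on an aromatic carbon, with the methoxy on an aromatic carbon ortho to a methoxy group and meta to a nitro group. For the measured compounds named here, only one measured step bears on this, the same exchange made on the shared core rather than on this ring: a 3.7-fold higher number from compound 1 to compound 2 (0.56 log units; beyond the scatter). That modest step is a loose guide, since the site differs. The step expected in this assay is a 1.7-fold higher number from compound 1 to compound 3 (0.24 log units; within the scatter), smaller than the measured one and in the same direction, towards a weaker inhibitor. The estimate for compound 3 is 10000 nM, with an expected range from 3500 nM to 30000 nM.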

Compound 3, half-maximal inhibitory concentration: 13000 nM
Compound 3: the middle estimate sits 1.3-fold (0.11 log units) below what was measured, and the stated range covers the measured number.
By their numbers in this assay, from the lowest: compound 1; then compounds 3 and 2 (each within the scatter of the next).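

In this assay, methoxy in place of hydrogen on the nitro-bearing ring, ortho to a methoxy group and meta to a nitro group, gives a 2.2-fold higher number from compound 1 to compound 3 (0.35 log units; beyond the scatter). The exchange has now been read at a second site, and this step, like the one on the shared core, a 3.7-fold higher number from compound 1 to compound 2 (0.56 log units; beyond the scatter), goes towards a weaker inhibitor, with both beyond the scatter. No measurement shown here accounts for either step.

At this position the compounds shown carry only hydrogen or methoxy, which leaves open what a hydroxyl, a fluorine atom or an amine would do there. From the compounds shown here alone, it also remains open whether the two methoxy exchanges would add up if both stood in one compound.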